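Swapping fluoro for ethoxy on the free-amine compound

The source may hold more compounds than are shown below. What is called first, only, known or untested is meant among the compounds shown, and "the series" means these compounds.

Values in an ADME assay on CCRF-CEM cells (Homo sapiens) for antiproliferative activity, with a stated time of 48 h; on this read-out lower numbers stand for stronger inhibition and higher numbers for weaker inhibition:
compound 1 `C=C(Br)C(=O)Nc1ccc(/C=C/C(=O)c2ccc(F)cc2)cc1`: 1100 nM
compound 2 `C=C(Br)C(=O)Nc1ccc(/C=C/C(=O)c2cccs2)cc1`: 730 nM
compound 3 `Nc1ccc(/C=C/C(=O)c2ccc(F)cc2)cc1`: 39000 nM

Among these three, compound 3 carries the highest number, at 39000 nM. The next compound to be read is compound 4 `CCOc1ccc(C(=O)/C=C/c2ccc(N)cc2)cc1`, which has ethoxy in place of fluoro on an aromatic carbon relative to compound 3: ethoxy in place of fluoro on an aromatic carbon.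

Within the data shown here, no measured step makes this exchange, so the evidence is indirect. The closest is a 1.5-fold lower number from compound 1 to compound 2 (0.18 log units; within the scatter), which replaces the 4-fluorophenyl group with thiophen-2-yl on the carbonyl carbon. That step stays within the scatter, but it was measured with the (1-bromoethenyl)carbonyl group on the nitrogen, which compound 3 lacks. The other step, a 35-fold higher number from compound 1 to compound 3 (1.55 log units; beyond the scatter), is large, but it concerns that group on the nitrogen and leaves the fluoro untouched. It therefore sets where compound 3 stands and says nothing about the size of the present change.

With only the first step as a guide, no shift beyond the scatter is expected in this assay. The expected outcome is a 1.1-fold lower number from compound 3 to compound 4 (0.05 log units; within the scatter). For compound 4 the estimated value is 35000 nM, with an expected range of 14000 nM to 80000 nM.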

Compound 4, half-maximal inhibitory concentration: 15000 nM
For compound 4 the middle estimate is 2.3-fold (0.37 log units) above the measured one; the range from low to high includes it.
By their numbers in this assay, from the lowest: compounds 2 and 1 (each within the scatter of the next); then compound 4; then compound 3.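

With the free amine on the nitrogen, the aromatic carbon para to a large group responds to substitution in this assay: ethoxy in place of fluoro gives a 2.6-fold lower number from compound 3 to compound 4 (0.41 log units; beyond the scatter), a modest step beyond the scatter. The earlier change on this side of the shared core, a 1.5-fold lower number from compound 1 to compound 2 (0.18 log units; within the scatter), replaced the whole 4-fluorophenyl group and carried the (1-bromoethenyl)carbonyl group on the nitrogen, so it did not isolate this position, and the new step remains much smaller than a 35-fold higher number from compound 1 to compound 3 (1.55 log units; beyond the scatter). No measurement at hand accounts for the shift from fluoro to ethoxy.

Among these compounds, it remains open whether ethoxy in place of fluoro gives a step of similar size and direction when the (1-bromoethenyl)carbonyl group is on the nitrogen, as the free-amine pair is the only direct reading of this exchange. Also open, going by these compounds, is whether the step follows the oxygen or the longer chain, a question that hydroxy, methoxy, ethyl or butoxy at the same aromatic carbon would help to separate.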